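This account rests on a few compounds, and the source may have more. Where it says the series, first, only, none or still open, it means among the compounds named here.

Measured so far in an assay on membranes from Cortex for displacement of a labelled ligand from Sigma non-opioid intracellular receptor 1 (Cavia porcellus), read by scintillation counting, with a stated time of 120 min; a higher number here means a weaker inhibitor, a lower number a stronger inhibitor:
Compound 1, `Fc1ccc(C(SCCNC2CCN(Cc3ccccc3)CC2)c2ccc(F)cc2)cc1`, gives 3.81 nM.
Compound 2, `Fc1ccc(CN2CCC(NCCSC(c3ccc(F)cc3)c3ccc(F)cc3)CC2)cc1`, gives 13.3 nM.
Compound 3, `[O-][S+](CCNC1CCN(Cc2ccc(F)cc2)CC1)C(c1ccc(F)cc1)c1ccc(F)cc1`, gives 26.5 nM.

Compound 3 has the highest of the three numbers; it lies within the scatter of compound 2, while compound 1 lies well below it. Compound 4, `[O-][S+](CCNC1CCN(CC(O)Cc2ccccc2)CC1)C(c1ccc(F)cc1)c1ccc(F)cc1`, differs from compound 3 in one place: 1-hydroxy-2-phenylethyl in place of 4-fluorophenyl on a saturated chain carbon bound to an amine nitrogen in a ring. Among the compounds with values here, the only measured step that touches this change is a 3.5-fold higher number from compound 1 to compound 2 (0.54 log units; beyond the scatter), which concerns the fluorine that here leaves; nothing measured speaks to the 1-hydroxy-2-phenylethyl that enters. On that partial basis a small step is expected in this assay, its direction uncertain. Compound 4 is therefore estimated near 40 nM, between 10 nM and 150 nM. The expected step is a 1.5-fold higher number from compound 3 to compound 4 (0.18 log units; within the scatter).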

Compound 4, inhibition constant: 351 nM
Compound 4: middle estimate off by 8.8-fold (0.94 log units), on the low side, and the stated range ends below it.
By their numbers in this assay, from the lowest: compound 1; then compounds 2 and 3 (each within the scatter of the next); then compound 4.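

In this assay, exchanging 4-fluorobenzyl for 2-hydroxy-3-phenylpropyl gives a 13-fold higher number from compound 3 to compound 4 (1.12 log units; beyond the scatter), a much larger change than the fluorine step alone, which was a 3.5-fold higher number from compound 1 to compound 2 (0.54 log units; beyond the scatter). This position is therefore sensitive to more than the presence of one fluorine. Nothing available shows whether the added hydroxyl, the longer chain or the lost fluorine is responsible. Still open, on these data alone, is how each part contributes: a plain 3-phenylpropyl group would test the chain without the hydroxyl, while 2-hydroxy-3-(4-fluorophenyl)propyl would test the chain and hydroxyl with the fluorine retained.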